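The source may hold more compounds than are shown below. What is called first, only, known or untested is meant among the compounds shown, and "the series" means these compounds.

Of the compounds shown here, three built on one shared core have been measured so far. Compound 1 `O=C(Nc1cccc(-n2cc(-c3ccncc3)c(-c3ccc(Cl)c(O)c3)n2)c1)Nc1cccc(C(F)(F)F)c1` in a functional assay on HCT-116 cells (Homo sapiens) for inhibition, read by sulforhodamine B assay, with a stated time of 48 h (a higher number here means a weaker inhibitor of growth, a lower number a stronger inhibitor of growth), gives 8260 nM. Compound 2 `COc1cc(-c2nn(-c3cccc(NC(=O)Nc4cc(C(F)(F)F)cc(C(F)(F)F)c4)c3)cc2-c2ccncc2)ccc1Cl` in this assay gives 1760 nM, and compound 3 `COc1cc(-c2nn(-c3cccc(NC(=O)Nc4cccc(C(F)(F)F)c4)c3)cc2-c2ccncc2)ccc1Cl` in this assay gives 7170 nM. Compound 2 therefore shows the lowest number of the three, which here means the strongest inhibition of cell growth; its steps to compound 3 and to compound 1 are both beyond the scatter, so this ranking is real and not noise.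

Compound 4 `O=C(Nc1cccc(-n2cc(-c3ccncc3)c(-c3ccc(Cl)c(O)c3)n2)c1)Nc1cc(C(F)(F)F)cc(C(F)(F)F)c1` has not yet been measured. It differs from compound 2 in one place: hydrogen in place of methyl on an oxygen on an aromatic ring. The same change, taken in the opposite direction, is already on record between two of the measured compounds: a 1.2-fold lower number from compound 1 to compound 3 (0.06 log units; within the scatter). That step lies within the scatter, so exchanging methyl and hydrogen on that oxygen made no clear difference in that pair. The other measured step, a 4.1-fold higher number from compound 2 to compound 3 (0.61 log units; beyond the scatter), concerns a different part of the molecule and does not speak directly to this change.

Compound 4 is expected to behave much like compound 2, with an estimated step of a 1.1-fold higher number from compound 2 to compound 4 (0.06 log units; within the scatter). The estimate for compound 4 in this assay is 2000 nM, with a range from 900 nM to 4500 nM.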

Compound 4, concentration for total growth inhibition: 1110 nM
Compound 4: middle estimate off by 1.8-fold (0.26 log units), on the high side; the range from low to high includes it.
By their numbers in this assay, from the lowest: compounds 4 and 2 (each within the scatter of the next); then compounds 3 and 1 (each within the scatter of the next).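

With the hydroxy group of compound 4 in place of the methoxy group of compound 2, this assay gives a 1.6-fold lower number from compound 2 to compound 4 (0.20 log units; within the scatter), so this small exchange on an oxygen on an aromatic ring again makes no clear difference, now on a second core: the same change on two cores in this assay, a 1.2-fold lower number (0.06 log units; within the scatter) from compound 1 to compound 3 and a 1.6-fold higher number (0.20 log units; within the scatter) from compound 4 to compound 2, 1.8-fold (0.26 log units) apart, within the scatter of two such steps. The result also tests the other change on a new background: a 7.4-fold lower number from compound 1 to compound 4 (0.87 log units; beyond the scatter) shows that adding a trifluoromethyl group lowers the number when the oxygen carries hydrogen, and the effect matches the one already seen when it carries methyl: the same change on two cores in this assay, a 4.1-fold higher number (0.61 log units; beyond the scatter) from compound 2 to compound 3 and a 7.4-fold higher number (0.87 log units; beyond the scatter) from compound 4 to compound 1, 1.8-fold (0.26 log units) apart, within the scatter of two such steps. Across these four compounds, the two changes therefore appear to act separately, with compounds 2 and 4 forming the low pair and compounds 1 and 3 the high pair, and no compound here goes against this pattern.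

The compounds shown place only methyl or hydrogen on this oxygen, so they leave open whether a longer chain, such as ethyl, would also make no clear difference. They also leave open what an amine in place of the hydroxy group would do to growth inhibition.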